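Removing a Fluoro Group from a Soluble Spirocyclic Amide

The compounds below may be only part of what the source reports. "The series", "measured", "known", "first", "only" and "open" are said of these compounds alone.

Compound 1 `CN(C)C(=O)CCNC(=O)c1cc(-c2ccc(F)cc2)no1` and compound 2 `CC(=O)N1CC2(CC(NC(=O)c3cc(-c4ccc(F)cc4)no3)C2)C1` share the same core, an amide-linked five-membered heteroaromatic ring bearing a 4-fluorophenyl group. Both were tested in a physicochemical assay for solubility, at pH 1.2; a higher number here means a more soluble compound, a lower number a less soluble compound. In this assay compound 1 gives > 100 ug/mL, which is a limit of the assay rather than a number. In this assay compound 2 likewise gives > 100 ug/mL, again a limit and not a number. Compound 2 therefore stands at the limit of > 100 ug/mL in this assay, at which 2 of the 2 values shown sit, so no ordering between the two measured compounds can be read.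

Compound 3 `CC(=O)N1CC2(CC(NC(=O)c3cc(-c4ccccc4)no3)C2)C1` differs from compound 2 by hydrogen in place of fluoro on an aromatic carbon. Among the measured compounds shown here, no measured step of this kind exists here. The step from compound 2 to compound 3 is expected to be small, a step that the limit leaves unreadable from compound 2 to compound 3, not beyond the scatter. Compound 3 is expected to reach about 150 ug/mL in this assay, within a range from 60 ug/mL to 400 ug/mL.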

Compound 3, solubility: > 100 ug/mL
Compound 3 gave a limit, no number; the forecaster's own chance of this, stated with the estimate: 70%; the middle value is on the limit's open side.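

In this assay compound 2 and compound 3 both stand at a limit and not at a number, so no new step can be read between them: the limit of > 100 ug/mL in this assay, at which 3 of the 3 values shown sit. The compounds shown leave open how far each lies past that limit, and whether going from 4-fluorophenyl to phenyl changes the read-out at all.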